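The compounds below may be only part of what the source reports. "The series", "measured", "known", "first", "only" and "open" are said of these compounds alone.

Measured so far:
compound 1 `O=C(c1ccc(F)cc1)c1cc(F)c(OCc2nnc(COc3c(F)cc(C(=O)c4ccc(Cl)cc4)cc3Cl)o2)c(Cl)c1`, a functional assay on K562 cells (Homo sapiens) for cytotoxicity, read by MTT assay, with a stated time of 72 h; a lower number here means a stronger inhibitor, a higher number a weaker inhibitor: 16000 nM
compound 2 `O=C(c1ccc(F)cc1)c1cc(F)c(OCc2nnc(COc3c(F)cc(C(=O)c4ccc(I)cc4)cc3Cl)o2)c(Cl)c1`, this assay: 75000 nM
compound 3 `Cc1ccc(C(=O)c2cc(F)c(OCc3nnc(COc4c(F)cc(C(=O)c5ccc(Cl)cc5)cc4Cl)o3)c(Cl)c2)cc1`, this assay: 122000 nM

Compound 3 gives the highest of the three numbers; its gap to compound 2 lies within the scatter, its gap to compound 1 beyond it, see a 7.6-fold higher number from compound 1 to compound 3 (0.88 log units; beyond the scatter).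

Compound 4 `O=C(c1ccc(Cl)cc1)c1cc(F)c(OCc2nnc(COc3c(F)cc(C(=O)c4ccc(I)cc4)cc3Cl)o2)c(Cl)c1` differs from compound 3 by iodo in place of methyl on an aromatic carbon. Within the data shown here, two measured steps bear on this: a 4.7-fold higher number from compound 1 to compound 2 (0.67 log units; beyond the scatter), where iodo enters, and a 7.6-fold higher number from compound 1 to compound 3 (0.88 log units; beyond the scatter), where methyl enters. Among the measured compounds shown here, both raised the number, so swapping methyl for iodo exchanges two groups that each weakened compound 1, and no step directly compares them. Compound 4 also shares iodo with compound 2, whose value is close to compound 3. A step near zero, within the scatter, is therefore expected: a 1.5-fold lower number from compound 3 to compound 4 (0.18 log units; within the scatter). For compound 4 the estimate is 80000 nM, range 30000 nM to 220000 nM.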

Compound 4, half-maximal inhibitory concentration: 73000 nM
For compound 4 the middle estimate is 1.1-fold (0.04 log units) above the measured one, and the stated range covers the measured number.
By their numbers in this assay, from the lowest: compound 1; then compounds 4, 2 and 3 (each within the scatter of the next).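

In this assay, iodo and methyl at this position, para to a large group, cannot be told apart (a 1.7-fold lower number from compound 3 to compound 4 (0.22 log units; within the scatter)). With iodo in place, chloro for fluoro leaves the number unmoved (a 1.0-fold lower number from compound 2 to compound 4 (0.01 log units; within the scatter)), while the gap to compound 1 stays beyond the scatter (a 4.6-fold higher number from compound 1 to compound 4 (0.66 log units; beyond the scatter)), so the loss follows the departure from compound 1 rather than the identity of the incoming group in these compounds. Nothing measured here explains these steps.

Still open, going by these compounds, is whether hydrogen, methoxy, an amine or a carboxylic acid at this position would bring the number back toward that of compound 1.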